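The source may hold more compounds than are shown below. What is called first, only, known or untested is meant among the compounds shown, and "the series" means these compounds.

In a functional assay on HCT-116 cells (Homo sapiens) for cytotoxicity, read by MTT assay, with a stated time of 72 h (a higher number here means a weaker inhibitor, a lower number a stronger inhibitor), three compounds sharing one core have been measured: compound 1 `CC(C)(C)NC(=S)N/N=C1\CC(c2ccc(O)cc2)Oc2cc(O)ccc21` gives 25900 nM, compound 2 `Oc1ccc(C2C/C(=N\NC(=S)N3CCCC3)c3ccc(O)cc3O2)cc1` gives 52300 nM, and compound 3 `CCCN(CCC)C(=S)N/N=C1\CC(c2ccc(O)cc2)Oc2cc(O)ccc21` gives 41900 nM. Compound 3 lies within the scatter of both others, with a 1.6-fold higher number from compound 1 to compound 3 (0.21 log units; within the scatter) and a 1.2-fold lower number from compound 2 to compound 3 (0.10 log units; within the scatter). The next structure, compound 4 `Oc1ccc(C2C/C(=N\NC(=S)N3CCCCC3)c3ccc(O)cc3O2)cc1`, has piperidin-1-yl in place of dipropylamino on a thiocarbonyl carbon. All three measured steps are changes at this same carbon, and the only one beyond the scatter, a 2.0-fold higher number from compound 1 to compound 2 (0.31 log units; beyond the scatter), is modest. No step beyond the scatter is therefore expected, and the estimate is a 1.1-fold higher number from compound 3 to compound 4 (0.03 log units; within the scatter). For compound 4 the expected value is 45000 nM, with an estimated range of 24000 nM to 80000 nM.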

Compound 4, half-maximal inhibitory concentration: 50900 nM
Estimate against measurement, compound 4: 1.1-fold (0.05 log units) below; the measured number falls inside the stated range.
By their numbers in this assay, from the lowest: compounds 1, 3, 4 and 2 (each within the scatter of the next, the first and the last beyond it).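

In this assay replacing the open dipropylamino group with the piperidin-1-yl ring on the thiocarbonyl carbon leaves the result within the scatter (a 1.2-fold higher number from compound 3 to compound 4 (0.08 log units; within the scatter)), and so does enlarging the ring from pyrrolidin-1-yl (a 1.0-fold lower number from compound 2 to compound 4 (0.01 log units; within the scatter)). The step from the (tert-butyl)amino group also stays within the scatter (a 2.0-fold higher number from compound 1 to compound 4 (0.29 log units; within the scatter)), so among these compounds, only the step from compound 1 to compound 2 lies beyond it. No measurement here offers an explanation for these results. Still open, from the compounds shown here alone, is how a morpholin-4-yl or piperazin-1-yl ring would compare on this carbon. A longer chain ending in a carboxylic acid also remains untested among the compounds shown.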